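The source may report more compounds than this note shows. Statements on the series, on what has been measured and on what is new or still open speak of the compounds shown alone.

Compound 2 `[SeH]c1nc(NCc2ccccc2)c2ccccc2n1` gives 3540 nM in an ADME assay on BEAS-2B cells (Homo sapiens) for cytotoxicity, read by MTT assay, with a stated time of 72 h; a lower number here means a stronger inhibitor of growth, a higher number a weaker inhibitor of growth. Compound 1 `CCCCC[Se]c1nc(NCc2ccccc2)c2ccccc2n1` differs from compound 2 by pentyl in place of hydrogen on a selenium, and in this assay compound 1 gives 44100 nM, so that a 12-fold higher number from compound 2 to compound 1 (1.10 log units; beyond the scatter). Compound 3 `Nc1nc([SeH])nc2ncccc12` has a different core from compound 2; how the two cores differ is not broken down here. In this assay compound 3 gives 5890 nM. Compound 4 `CCCCC[Se]c1nc(N)c2cccnc2n1` stands to compound 3 as compound 1 stands to compound 2, the change being (pentyl in place of hydrogen on a selenium), on a selenium whose other neighbours are aromatic carbon in both pairs. If the change acts on compound 3 as it did on compound 2, compound 4 is expected to give a higher number, the estimated step being a 10-fold higher number from compound 3 to compound 4 (1.01 log units; beyond the scatter), because a 12-fold higher number from compound 2 to compound 1 (1.10 log units; beyond the scatter) gives both direction and size. Compound 4 is therefore estimated at 60000 nM, within 20000 nM to 150000 nM.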

Compound 4, concentration for 50% growth inhibition: 16300 nM
Beside the measured number, compound 4's estimate is 3.7-fold (0.57 log units) above it; the measured number lies below the stated range.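

In this assay, pentyl in place of hydrogen on a selenium again gives a higher number, here a 2.8-fold higher number from compound 3 to compound 4 (0.44 log units; beyond the scatter). The direction of the step therefore holds on both cores, but its size does not carry over from one core to the other: the same change on two cores in this assay, a 12-fold higher number (1.10 log units; beyond the scatter) from compound 2 to compound 1 and a 2.8-fold higher number (0.44 log units; beyond the scatter) from compound 3 to compound 4, 4.5-fold (0.65 log units) apart, beyond the scatter of two such steps. These two pairs do not show which difference between the cores goes with the difference in size, nor how the change would behave on any further core.

Only hydrogen and pentyl stand on the selenium in the compounds shown, so it remains open how a shorter chain such as ethyl, a longer chain such as octyl, or a benzyl group would behave there. From the compounds shown here alone, whether the gap between the two cores would persist with such groups also remains open.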